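The source may hold more compounds than are shown below. What is called first, only, known or untested is meant among the compounds shown, and "the series" means these compounds.

Three compounds share one core and differ only in the aromatic group attached to the five-membered ring. Compound 1 is `Cc1cc(NCc2ccccn2)n2ncc(-c3ccc(N(C)C)cc3)c2n1`, compound 2 is `Cc1cc(NCc2ccccn2)n2ncc(-c3ccc(C#N)cc3)c2n1` and compound 3 is `Cc1cc(NCc2ccccn2)n2ncc(-c3ccccc3F)c2n1`. Solubility was read in a physicochemical assay for solubility, read by HPLC, using the shake flask method, measured as kinetic solubility, with a stated time of 2 h, at pH 7.4; on this read-out higher numbers stand for higher solubility and lower numbers for lower solubility. In this assay compound 1 gives < 5000 nM, which is a limit of the assay and not a number. Compound 2 likewise gives < 5000 nM, again a limit. Going by the values given here, compound 3 is the only one with a number and gives 5000 nM; the other two values sit at the limit of < 5000 nM in this assay, at which 2 of the 3 values shown sit. The step of a number no lower from compound 1 to compound 3 (the limit leaves the size open) and the step of a number no lower from compound 2 to compound 3 (the limit leaves the size open) are therefore open in size, and the step that the two limits leave unreadable from compound 1 to compound 2 cannot be read at all.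

Compound 4 is `Cc1cc(NCc2ccccn2)n2ncc(-c3ccc(F)c(Cl)c3)c2n1`. The change from compound 3 is 3-chloro-4-fluorophenyl in place of 2-fluorophenyl on an aromatic carbon. Among the compounds with values here, none of the measured steps adds or removes a chlorine, so no measured step bears directly on it. The estimate for compound 4 is 3000 nM, with a range from 1000 nM to 8000 nM, which means an expected step of a 1.7-fold lower number from compound 3 to compound 4 (0.22 log units; within the scatter), within the scatter or modestly downward.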

Compound 4, solubility: < 5000 nM
Compound 4: only a limit was reported; the forecaster's own chance of this, stated with the estimate: 60%; the middle value does not contradict the limit.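

Compound 4 is a third compound whose aromatic group on the shared core leaves only a limit, not a number, in this assay. Going by these compounds, putting 3-chloro-4-fluorophenyl in place of 2-fluorophenyl gives a number no higher from compound 3 to compound 4 (the limit leaves the size open), so adding a chlorine and moving the fluorine brings no readable gain over compound 3, and the size of the step stays open; the steps to compound 4 from compound 1 and from compound 2 cannot be read, as both ends of each are limits. The set now crowds at a single end of the read-out: the limit of < 5000 nM in this assay, at which 3 of the 4 values shown sit.

On these data alone, how far compound 1, compound 2 and compound 4 lie from that limit remains unknown, so these three cannot be ranked. As far as these compounds go, whether an aromatic group carrying a carboxylic acid or a morpholine would give a number clear of the limit also stays open.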